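This account rests on a few compounds, and the source may have more. Where it says the series, first, only, none or still open, it means among the compounds named here.

Compound 3 `CCC(CC)(c1ccc(OCC(O)C(C)(C)Cc2ccccc2)c(C)c1)c1ccc(OC[C@@H](O)CO)c(C)c1` gives 11000 nM in an assay on HL-60 cells for activation of vitamin D3 receptor (Homo sapiens) (on this read-out lower numbers stand for an effect already at smaller amounts and higher numbers for an effect only at larger amounts of compound), the lower end of the two numbers at hand, though the gap to compound 1 lies within the scatter. Compound 1 `CCC(CC)(c1ccc(OCC(=O)C(C)(C)Cc2ccccc2)c(C)c1)c1ccc(OC[C@@H](O)CO)c(C)c1` gives 21000 nM in this assay. For compound 2 `CCC(CC)(c1ccc(OCC(=O)C(C)(C)CCCCc2ccccc2)c(C)c1)c1ccc(OC[C@@H](O)CO)c(C)c1` this assay returns only a limit, > 30000 nM. Compound 4 `CCC(CC)(c1ccc(OCC(O)C(C)(C)CCCCc2ccccc2)c(C)c1)c1ccc(OC[C@@H](O)CO)c(C)c1` differs from compound 3 by 3-phenylpropyl in place of phenyl on a saturated chain carbon, three bonds along the chain from an oxygen on a saturated carbon. The same change on the carbonyl pair reads an at least 1.4-fold higher number from compound 1 to compound 2 (0.15 log units; that floor lies within the scatter), and that step ended at the limit of > 30000 nM in this assay, at which 1 of the 3 values shown sits. On this basis the step to compound 4 is expected upward, of uncertain size, a 2.3-fold higher number from compound 3 to compound 4 (0.36 log units; beyond the scatter), with a real chance that this assay again reports only a limit. Compound 4 is estimated at 25000 nM, with a range of 10000 nM to 60000 nM.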

Compound 4, half-maximal effective concentration: > 30000 nM
Compound 4: a limit, no number (the forecaster's own chance of this, stated with the estimate: 40%); middle value at least 1.2-fold (0.07 log units) away from the limit.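

In this assay, 3-phenylpropyl in place of phenyl at this place now gives a step beyond the scatter on the core of compound 3, with an at least 2.7-fold higher number from compound 3 to compound 4 (0.43 log units; beyond the scatter). That step rests on a limit for compound 4, so it gives a floor and not a size, and a comparison with the carbonyl pair stays unresolved: the same change on two cores in this assay, an at least 1.4-fold higher number (0.15 log units; that floor lies within the scatter) from compound 1 to compound 2 and an at least 2.7-fold higher number (0.43 log units; beyond the scatter) from compound 3 to compound 4; the limit leaves it open whether they differ Both 3-phenylpropyl compounds now end at the assay's limit: the limit of > 30000 nM in this assay, at which 2 of the 4 values shown sit.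

Still open, on these data alone, is how far compound 2 and compound 4 lie past that limit. Also open, as far as these compounds go, is how an amine or a carboxylic acid in place of phenyl at this place would read.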